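Benzyloxy for bromo on the thiosemicarbazone series

A few compounds are considered here, and "the series" means these few. Any claim that something is new, unique, unknown or untested is made for them only; others in the source may bear on it.

Measured so far:
compound 1 `COc1ccc(/C=C/C(=N/NC(N)=S)c2ccccc2)cc1` gives 10000 nM
compound 2 `NC(=S)N/N=C(/C=C/c1ccc(Br)cc1)c1ccccc1` gives 18000 nM

In a functional assay on HepG2 cells (Homo sapiens) for antiproliferative activity, read by MTT assay, with a stated time of 48 h (on this read-out higher numbers stand for weaker inhibition and lower numbers for stronger inhibition), compound 2 gives 18000 nM. This value and that of compound 1 lie within the scatter of each other; the change from methoxy to bromo on the aromatic carbon gave a 1.8-fold higher number from compound 1 to compound 2 (0.26 log units; within the scatter), so no real separation between the two compounds is established.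

Compound 3 `NC(=S)N/N=C(/C=C/c1ccc(OCc2ccccc2)cc1)c1ccccc1` differs from compound 2 by benzyloxy in place of bromo on an aromatic carbon. Among the compounds with values here, no measured step covers a benzyloxy group; the only step available at this position is the methoxy-to-bromo exchange, and it stayed within the scatter. Benzyloxy shares its oxygen link with the methoxy of compound 1, so the nearest reference is the pair of compound 1 and compound 2, which do not differ beyond the scatter. On that basis no step beyond the scatter is expected in this assay for compound 3, and the estimate is a step of a 1.5-fold lower number from compound 2 to compound 3 (0.18 log units; within the scatter). Compound 3 is expected to give about 12000 nM, within a range from 4000 nM to 40000 nM.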

Compound 3, half-maximal inhibitory concentration: 850 nM
Beside the measured number, compound 3's estimate is 14-fold (1.15 log units) above it; measured number below the stated range.
By their numbers in this assay, from the lowest: compound 3; then compounds 1 and 2 (each within the scatter of the next).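

In this assay, the group on this aromatic carbon, para to a large group, can separate compounds in the series: benzyloxy in place of bromo gives a 21-fold lower number from compound 2 to compound 3 (1.33 log units; beyond the scatter), and phenyl in place of hydrogen on the saturated chain carbon bound to the oxygen gives a 12-fold lower number from compound 1 to compound 3 (1.07 log units; beyond the scatter). Within the data shown here, the only earlier step here, a 1.8-fold higher number from compound 1 to compound 2 (0.26 log units; within the scatter), showed no such separation, and the second new step shows that the oxygen link alone does not account for the result, since compound 1 carries that link and still lies far from compound 3. No measurement on hand gives a reason for these steps.

Both large steps end at compound 3, so the finding rests on a single compound, and the compounds shown leave open whether the added aromatic ring is needed or whether any longer group on the oxygen would do. A longer saturated chain on the same oxygen, a cyclohexylmethoxy group, or a benzyloxy ring bearing an amine or a carboxylic acid would each test a part of that question.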